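The source may report more compounds than this note shows. Statements on the series, on what has been measured and on what is new or still open speak of the compounds shown alone.

Measured compounds:
Compound 1 `COc1ccc(O)c(C(=O)Nc2ccc(C#N)cc2)c1`: > 10000 nM
Compound 2 `N#Cc1ccc(NC(=O)c2cccc(Br)c2O)cc1`: 2910 nM

In a functional assay on HL-60 cells (Homo sapiens) for cytotoxicity, read by luminescence and CellTiter-Glo, with a stated time of 3 days (a lower number here means a stronger inhibitor, a higher number a weaker inhibitor), compound 1 gives only a limit of the assay, > 10000 nM, and not a number. Compound 2 gives a number, 2910 nM. Compound 3 `N#Cc1ccc(NC(=O)c2cc(Cc3ccccc3)ccc2O)cc1` has benzyl in place of methoxy on an aromatic carbon, para to a hydroxy group (benzyl in place of methoxy on an aromatic carbon). Within the data shown here, no measured step covers this change, so the expectation rests on compound 2 and its 2910 nM. A move beyond the scatter towards stronger inhibition in this assay is expected, and the estimated step is an at least 4.0-fold lower number from compound 1 to compound 3 (0.60 log units; beyond the scatter). For compound 3 the expected value is 2500 nM, with an estimated range of 600 nM to 10000 nM.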

Compound 3, half-maximal inhibitory concentration: 1740 nM
The estimate for compound 3 lay 1.4-fold (0.16 log units) above the measured number; low and high end bracket the measured number.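

Benzyl in place of methoxy on an aromatic carbon, para to a hydroxy group, gives an at least 5.7-fold lower number from compound 1 to compound 3 (0.75 log units; beyond the scatter) in this assay, which shows that this position can carry the larger group with a measurable value. Compound 1 gives > 10000 nM, which is a limit and not a number, so the step is only a bound and its true size stays unknown: the limit of > 10000 nM in this assay, at which 1 of the 3 values shown sits.

The compounds shown leave open how an amine or a carboxylic acid on this carbon would read, and whether a longer chain ending in the same ring would shift the number further. They also do not separate the effect of the aromatic ring from that of the added carbon atoms.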